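Cyclohexyl in Place of Pentyl on the Ester Oxygen

A few compounds are considered here, and "the series" means these few. Any claim that something is new, unique, unknown or untested is made for them only; others in the source may bear on it.

Three esters sharing one core have been tested in an ADME assay on RAW264.7 cells (Mus musculus) for cytotoxicity, read by MTT assay, with a stated time of 24 h; on this read-out lower numbers stand for higher toxicity in this test and higher numbers for lower toxicity in this test. Compound 1 `CC/C=C\C[C@H]1C(=O)C=C[C@H]1CC(=O)OCCCCC` gives 37 uM. Compound 2 `CC/C=C\C[C@H]1C(=O)C=C[C@H]1CC(=O)OCc1ccccc1` gives 31 uM, and compound 3 `CC/C=C\C[C@H]1C(=O)C=C[C@H]1CC(=O)Oc1ccc(O)cc1` gives 49 uM. Among these three numbers compound 1 stands second highest, its nearest neighbour being compound 2 and its furthest compound 3. The steps are small: a 1.2-fold lower number from compound 1 to compound 2 (0.08 log units; within the scatter), a 1.3-fold higher number from compound 1 to compound 3 (0.12 log units; within the scatter) and a 1.6-fold higher number from compound 2 to compound 3 (0.20 log units; within the scatter), each within the scatter, so nothing separates the three compounds on this read-out.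

Compound 4 `CC/C=C\C[C@H]1C(=O)C=C[C@H]1CC(=O)OC1CCCCC1` differs from compound 1 by cyclohexyl in place of pentyl on an oxygen next to a carbonyl group. Among the compounds with values here, no measured pair carries a cyclohexyl group, so the bearing of the measured steps is indirect: the three replacements already tried on the oxygen next to the carbonyl group, from pentyl to benzyl and to 4-hydroxyphenyl, all stayed within the scatter. Another saturated group of similar size at the same place is therefore expected to behave alike, and no step beyond the scatter is expected: a 1.1-fold higher number from compound 1 to compound 4 (0.03 log units; within the scatter). Compound 4 is estimated at 40 uM in this assay, with a range from 20 uM to 80 uM.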

Compound 4, half-maximal toxic concentration: 31 uM
For compound 4 the middle estimate is 1.3-fold (0.11 log units) above the measured one; the range from low to high includes it.
By their numbers in this assay, from the lowest: compounds 2, 4, 1 and 3 (each within the scatter of the next).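

Exchanging pentyl for cyclohexyl on the oxygen next to a carbonyl group gives a 1.2-fold lower number from compound 1 to compound 4 (0.08 log units; within the scatter) in this assay, so a non-aromatic ring of carbon only at this place reads the same as the open chain. Against the aromatic groups at the same place, cyclohexyl gives a 1.6-fold lower number from compound 3 to compound 4 (0.20 log units; within the scatter) when it replaces 4-hydroxyphenyl and no change at the digits printed from compound 2 to compound 4 (within the scatter) when it replaces benzyl, which extends the flat picture from chains and aromatic groups to a saturated ring: among these four compounds, neither a ring nor an aromatic group at this place separates one number from another. Nothing in the material at hand bears on why the four numbers stay so close together.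

Still open is whether an amine, a carboxylic acid or a much longer chain on this oxygen would carry the number beyond the scatter, since all four groups shown are built of carbon and hydrogen, apart from the single hydroxyl of 4-hydroxyphenyl. Going by these compounds, all four compounds also keep the shared core unchanged, so what a change within that core would do in this test remains unknown.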